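This account rests on a few compounds, and the source may have more. Where it says the series, first, only, none or still open, it means among the compounds named here.

Working notes on the series. Compound 1 `Cc1ccc(=O)n(CCCCCCC(=N)S)n1` and compound 2 `N=C(S)CCCCCCn1nc(-c2ccccc2)ccc1=O` share one core and the same seven-carbon chain ending in a thioamide. In a functional assay on the whole organism (stomach) with Rattus norvegicus as the target (a higher number here means that more compound is needed for the effect, a lower number that less compound is needed), compound 1 gives only a limit of the assay, > 100 mg/kg. In this assay compound 2 likewise gives only a limit of the assay, > 100 mg/kg. The step from compound 1 to compound 2, phenyl in place of methyl on an aromatic carbon, is therefore a step that the two limits leave unreadable from compound 1 to compound 2. Where compound 2 stands is known only as a limit; the limit of > 100 mg/kg in this assay, at which 2 of the 2 values shown sit, sums up what the two measured values show. Compound 3 `O=c1ccc(-c2ccccc2)nn1CCC(=S)N1CCCC1` differs from compound 2 by a group of 7 heavy atoms (5 carbon, 1 nitrogen, 1 sulfur; one five-membered non-aromatic ring with 1 hetero atom) in place of a group of 7 heavy atoms (5 carbon, 1 nitrogen, 1 sulfur; no ring), on a saturated chain carbon, two bonds along the chain from an aromatic nitrogen. Among the measured compounds shown here, no measured step bears on this change, and the one step that exists cannot be read, so no direction follows from it. The expected step from compound 2 to compound 3 is a number no higher from compound 2 to compound 3 (the limit leaves the size open). For compound 3 the estimate in this assay is 100 mg/kg, with a range from 30 mg/kg to 300 mg/kg.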

Compound 3, dose for half-maximal effect: > 100 mg/kg
Compound 3: a limit, no number (the forecaster's own chance of this, stated with the estimate: 65%); the middle value sits exactly at the limit.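

Compound 3 gives only a limit of the assay in this assay, > 100 mg/kg. The step between compound 2 and compound 3 therefore cannot be read. The compounds shown leave open at what dose any of them reaches the half-maximal effect, and whether either change matters: the limit of > 100 mg/kg in this assay, at which 3 of the 3 values shown sit.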